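Three Limits and a Chloro-for-Nitro Swap

A few compounds are considered here, and "the series" means these few. Any claim that something is new, unique, unknown or untested is made for them only; others in the source may bear on it.

Compound 1, `N#CC1=C(N)Oc2c(N)cc3nc4ccccc4nc3c2C12C(=O)N(Cc1cnnn1-c1ccc(Cl)cc1)c1ccccc12`, in an ADME assay on HUVEC cells (Homo sapiens) for antiproliferative activity, read by MTT assay, with a stated time of 48 h (a lower number here means a stronger inhibitor, a higher number a weaker inhibitor), gives > 50000 nM, which is a limit of the assay.
Compound 2, `N#CC1=C(N)Oc2c(N)cc3nc4ccccc4nc3c2C12C(=O)N(Cc1cnnn1-c1ccc([N+](=O)[O-])cc1)c1ccccc12`, in this assay gives > 50000 nM, again a limit of the assay.
Compound 3, `N#CC1=C(N)Oc2c(N)cc3nc4ccccc4nc3c2C12C(=O)N(Cc1cnnn1-c1ccc([N+](=O)[O-])cc1[N+](=O)[O-])c1ccccc12`, in this assay gives > 50000 nM, also a limit of the assay.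

The three measured compounds share one core and differ only in the substituted phenyl ring on the triazole. Compound 2 turns into compound 1 through (chloro in place of nitro on an aromatic carbon), and into compound 3 through (nitro in place of hydrogen on an aromatic carbon). None of these steps can be read: a step that the two limits leave unreadable from compound 2 to compound 1, a step that the two limits leave unreadable from compound 2 to compound 3, a step that the two limits leave unreadable from compound 1 to compound 3. The reason is the limit of > 50000 nM in this assay, at which 3 of the 3 values shown sit, so every comparison rests on limits alone.

Compound 4, `N#CC1=C(N)Oc2c(N)cc3nc4ccccc4nc3c2C12C(=O)N(Cc1cnnn1-c1ccc(Cl)cc1[N+](=O)[O-])c1ccccc12`, is not yet measured. It arises from compound 3 through (chloro in place of nitro on an aromatic carbon), the same kind of change as that from compound 2 to compound 1, though here the place is also meta to a nitro group. Because a step that the two limits leave unreadable from compound 2 to compound 1 could not be read, there is no measured size to carry over.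

From compound 3 to compound 4 the expected step is a number no higher from compound 3 to compound 4 (the limit leaves the size open), which rests on compound 3 giving > 50000 nM and on compound 1 giving > 50000 nM with the same kind of change in place. Compound 4 is therefore expected in this assay at about 50000 nM, and most likely the assay will again report only a limit.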

Compound 4, half-maximal inhibitory concentration: > 50000 nM
Compound 4 ended at the assay's limit; the forecaster's own chance of this, stated with the estimate: 90%; the middle value sits exactly at the limit.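

Going by these compounds alone, compound 4 gives a limit of the assay, as do compound 1, compound 2 and compound 3, so no step between compound 4 and any of these three can be read in this assay, because every comparison rests on limits alone: the limit of > 50000 nM in this assay, at which 4 of the 4 values shown sit.

The four compounds leave open whether chloro in place of nitro, or any other change on this phenyl ring, alters the activity in this assay at all.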